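Cytotoxicity of an oxadiazoline series: a 4-chlorophenyl analogue

A few compounds are considered here, and "the series" means these few. Any claim that something is new, unique, unknown or untested is made for them only; others in the source may bear on it.

Compounds measured in an ADME assay on HeLa cells (Homo sapiens) for cytotoxicity, read by MTT assay, with a stated time of 72 h; a lower number here means a stronger inhibitor of growth, a higher number a weaker inhibitor of growth:
compound 1 `O=C(/C=C\c1ccccc1[N+](=O)[O-])N1N=C(c2ccncc2)OC1c1c[nH]c2ccccc12`, which gives > 30 ug/mL, a limit of the assay;
compound 2 `O=C(/C=C\c1cccc([N+](=O)[O-])c1)N1N=C(c2ccncc2)OC1c1c[nH]c2ccccc12`, which gives > 30 ug/mL, also a limit;
compound 3 `O=C(/C=C\c1ccccc1Cl)N1N=C(c2ccncc2)OC1c1c[nH]c2ccccc12`, which gives > 30 ug/mL, again a limit.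

Compound 1 thus stands at the limit and not at a number, as do the two other measured compounds. Compound 4 `O=C(/C=C\c1ccc(Cl)cc1)N1N=C(c2ccncc2)OC1c1c[nH]c2ccccc12` differs from compound 1 by 4-chlorophenyl in place of 2-nitrophenyl on a double-bonded chain carbon bound to a double-bonded chain carbon. The measured steps that bear on this change are those at the same place: a step that the two limits leave unreadable from compound 1 to compound 2, a step that the two limits leave unreadable from compound 1 to compound 3 and a step that the two limits leave unreadable from compound 2 to compound 3, none of which can be read in size, because of the limit of > 30 ug/mL in this assay, at which 3 of the 3 values shown sit. A chlorine on the phenyl is already present in compound 3, which gives a limit, and moving a substituent around that phenyl has given no readable step in this assay. No step beyond the scatter is therefore expected; the expected step is a step that the limit leaves unreadable from compound 1 to compound 4. Compound 4 is estimated to give 40 ug/mL, with a range of 20 ug/mL to 100 ug/mL, and most likely once more only a limit.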

Compound 4, concentration for 50% growth inhibition: > 30 ug/mL
Compound 4 ended at the assay's limit (the forecaster's own chance of this, stated with the estimate: 85%); the middle value is on the limit's open side.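

No step can be read from compound 4 to compound 1, compound 2 or compound 3 in this assay, because all four compounds stop at the same limit: the limit of > 30 ug/mL in this assay, at which 4 of the 4 values shown sit. The compounds shown leave open how strongly any of them inhibits growth, and so whether changing the substituted phenyl makes any difference.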